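Propanoyl in place of hydrogen on compound 3

The source may report more compounds than this note shows. Statements on the series, on what has been measured and on what is new or still open speak of the compounds shown alone.

In a functional assay on MCF7 cells (Homo sapiens) for antiproliferative activity, read by MTT assay, with a stated time of 72 h (a lower number here means a stronger inhibitor, a higher number a weaker inhibitor), compound 1 `CC(=O)Oc1ccc(C(=O)C2=C3OC(C)(C)[C@@H](CC=C(C)C)C[C@@]34C[C@@H](CC=C(C)C)C(C)(C)[C@H]3CCC(C)(C)O[C@]34OC2=O)cc1OC(C)=O` gives 4830 nM, compound 2 `CC(C)=CC[C@H]1C[C@]23C[C@@H](CC=C(C)C)C(C)(C)[C@H]4CCC(C)(C)O[C@]42OC(=O)C(C(=O)c2ccc(OC(=O)c4ccc(F)cc4)c(OC(=O)c4ccc(F)cc4)c2)=C3OC1(C)C` gives 16800 nM and compound 3 `CC(C)=CC[C@H]1C[C@]23C[C@@H](CC=C(C)C)C(C)(C)[C@H]4CCC(C)(C)O[C@]42OC(=O)C(C(=O)c2ccc(O)c(O)c2)=C3OC1(C)C` gives 13500 nM. Compound 2 and compound 3 lie within the scatter of each other, and compound 3 sits above compound 1 by a gap beyond the scatter. Compound 4 `CCC(=O)Oc1cc(C(=O)C2=C3OC(C)(C)[C@@H](CC=C(C)C)C[C@@]34C[C@@H](CC=C(C)C)C(C)(C)[C@H]3CCC(C)(C)O[C@]34OC2=O)ccc1O` carries propanoyl in place of hydrogen on an oxygen on an aromatic ring of compound 3 (propanoyl in place of hydrogen on an oxygen on an aromatic ring). Within the data shown here, no measured pair isolates this change. The esters point both ways, with compound 1 at 4830 nM and compound 2 at 16800 nM. The expected 1.5-fold lower number from compound 3 to compound 4 (0.18 log units; within the scatter) is small, towards a lower number, and may stay within the scatter. Compound 4 is estimated at 9000 nM, with an expected range of 4000 nM to 19000 nM.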

Compound 4, half-maximal inhibitory concentration: > 20000 nM
Compound 4: no number, only a limit (the forecaster's own chance of this, stated with the estimate: 5%); at least 2.2-fold (0.34 log units) between middle value and limit.
By their numbers in this assay, from the lowest: compound 1; then compounds 3 and 2 (each within the scatter of the next). At a limit, above all of these: compound 4.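

In this assay compound 4 gives > 20000 nM, which is a limit of the assay and not a number. Hydroxy to propanoyloxy at this oxygen on the aromatic ring gives an at least 1.4-fold higher number from compound 3 to compound 4 (0.17 log units; that floor lies within the scatter), so this first single-change pair in the series shows no move towards a lower number, though only a floor is known for the step. The true size of the step stays unresolved at the top of the range: the limit of > 20000 nM in this assay, at which 1 of the 4 values shown sits.

Still open, from the compounds shown here alone, is how far compound 4 lies past its limit. Also open, going by these compounds, is whether an amine or a carboxylic acid on a longer chain at this oxygen would behave like propanoyl.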